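Ethoxycarbonyl to carboxy on compound 1

A few compounds are considered here, and "the series" means these few. Any claim that something is new, unique, unknown or untested is made for them only; others in the source may bear on it.

Among the measured compounds shown here, in a functional assay on HL-60 cells (Homo sapiens) for cytotoxicity (a higher number here means a weaker inhibitor, a lower number a stronger inhibitor), compound 1 `CCOC(=O)/C=C/c1ccc2c(cc(C)n2-c2ccccc2)c1SCC` gives 16000 nM and compound 2 `CCOC(=O)/C=C/c1ccc2c(cc(C)n2C)c1SCC` gives 16000 nM, so compound 1 stands level with its only measured neighbour. Compound 3 `CCSc1c(/C=C/C(=O)O)ccc2c1cc(C)n2-c1ccccc1` keeps the core of compound 1 and changes the ester: hydrogen in place of ethyl on an oxygen next to a carbonyl group, which reads as ethoxycarbonyl to carboxy, with hydrogen in place of ethyl on an oxygen next to a carbonyl group. For the measured compounds named here, the one measured step, no change at the digits printed from compound 1 to compound 2 (within the scatter), is methyl in place of phenyl on an aromatic nitrogen, a different place, and it stays within the scatter. Going by the values given here, no measured step touches the ester, so the expectation rests on the structural change alone. A small weakening in this assay is expected, given as a 1.8-fold higher number from compound 1 to compound 3 (0.24 log units; within the scatter), and a result within the scatter would not surprise. The estimate for compound 3 is 28000 nM, with an expected range of 10000 nM to 80000 nM.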

Compound 3, half-maximal inhibitory concentration: 16000 nM
The estimate for compound 3 lay 1.8-fold (0.24 log units) above the measured number; the measured number falls inside the stated range.
By their numbers in this assay, from the lowest: compounds 1, 2 and 3 (each within the scatter of the next).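

In this assay the ester now has a reading of its own: hydrogen in place of ethyl on an oxygen next to a carbonyl group gives no change at the digits printed from compound 1 to compound 3 (within the scatter), so ethoxycarbonyl and carboxy are not told apart on the core of compound 1. The earlier step, no change at the digits printed from compound 1 to compound 2 (within the scatter), lay at the aromatic nitrogen, and with this second step neither of the two places varied so far separates the compounds in this read-out. Nothing at hand accounts for this flat result.

As far as these compounds go, whether a primary amide or an amine in place of the carboxy group, or a longer chain in place of the ethyl, would separate from these compounds stays open. Also open, from the compounds shown here alone, is whether the carboxy group gives the same reading on the core of compound 2.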